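Aryl swap on the amide nitrogen: working notes

The compounds below may be only part of what the source reports. "The series", "measured", "known", "first", "only" and "open" are said of these compounds alone.

Values in a functional assay on K562 cells (Homo sapiens) for cytotoxicity, with a stated time of 72 h; a lower number here means a stronger inhibitor, a higher number a weaker inhibitor:
- Compound 1 `C[C@H](NC(=O)c1cc(Cl)ccc1O)C(=O)Nc1cccc(Cl)c1`: > 10000 nM
- Compound 2 `CC(C)[C@H](NC(=O)c1cc(Cl)ccc1O)C(=O)Nc1cccc(Cl)c1`: > 10000 nM
- Compound 3 `CC(C)[C@@H](NC(=O)c1cc(Cl)ccc1O)C(=O)Nc1cccc(Cl)c1`: > 10000 nM

All three entries are limits and not numbers. Compound 2 therefore has no readable position, only its limit of > 10000 nM.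

Compound 4 `COc1ccc(NC(=O)[C@@H](NC(=O)c2cc(Cl)ccc2O)C(C)C)cc1` carries 4-methoxyphenyl in place of 3-chlorophenyl on an amide-type nitrogen.

The measured steps are a step that the two limits leave unreadable from compound 1 to compound 2 and a step that the two limits leave unreadable from compound 2 to compound 3. Neither alters the group on that nitrogen, and neither offers a size to carry over.

The expected change in this assay is a step that the limit leaves unreadable from compound 2 to compound 4, with no direction supported by the data. Compound 4 is expected to report only a limit, and its estimate is 15000 nM, range 5000 nM to 40000 nM.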

Compound 4, half-maximal inhibitory concentration: > 10000 nM
Compound 4 ended at the assay's limit; the forecaster's own chance of this, stated with the estimate: 80%; the middle value does not contradict the limit.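

Compound 4 reports only a limit, > 10000 nM, and no step can be read between it and compound 2, which is also only a limit. The compounds shown leave open whether any group on that amide-type nitrogen gives a readable value.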